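Chain substituent two bonds from the ring nitrogen: compound 4 outlook

The compounds below may be only part of what the source reports. "The series", "measured", "known", "first", "only" and "open" are said of these compounds alone.

Compound 3 `CCn1c(=O)n(C2OC(CO)[C@@H](O)[C@H]2O)c2nc(N)nc(O)c21` gives the largest maximal response of the three measured compounds in a functional assay on the whole organism with Mus musculus as the target (a higher number here means a larger maximal response, a lower number a smaller maximal response), at 82%. Compound 2 `CN(C)CCCn1c(=O)n(C2OC(CO)[C@@H](O)[C@H]2O)c2nc(N)nc(O)c21` gives 63%, and compound 1 `Nc1nc(O)c2c(n1)n(C1OC(CO)[C@@H](O)[C@H]1O)c(=O)n2Cc1ccc(Cl)c(Cl)c1` gives 0%. The two large steps, a number 82 percentage points higher from compound 1 to compound 3 (beyond the scatter) and a number 63 percentage points higher from compound 1 to compound 2 (beyond the scatter), both remove the 3,4-dichlorophenyl and do not speak to the present question. The step that bears on it is a number 19 percentage points higher from compound 2 to compound 3 (beyond the scatter), since compound 4 `Nc1nc(O)c2c(n1)n(C1OC(CO)[C@@H](O)[C@H]1O)c(=O)n2CCN1CCCCC1` differs from compound 3 by piperidin-1-yl in place of hydrogen on a saturated chain carbon, two bonds along the chain from an aromatic nitrogen, a change at the same place on the chain and in the opposite sense to that modest step. A modest decrease is therefore expected, and compound 4 is expected to show a number 20 percentage points lower from compound 3 to compound 4 (beyond the scatter). Compound 4 is estimated at 62%, within 45% to 78%.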

Compound 4, largest response reached (reported as maximal response), in percent of the reference or control that the assay uses: 0%
Compound 4: middle estimate off by 62 percentage points, on the high side, outside the stated range (below it).
By their numbers in this assay, from the lowest: compounds 1 and 4 (each within the scatter of the next); then compound 2; then compound 3.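

In this assay, piperidin-1-yl on a saturated chain carbon, two bonds along the chain from an aromatic nitrogen, abolishes the response (a number 82 percentage points lower from compound 3 to compound 4 (beyond the scatter)), a far larger loss than the earlier step at this place. The same group in place of (dimethylamino)methyl also costs a large step (a number 63 percentage points lower from compound 2 to compound 4 (beyond the scatter)), and the result stands level with the 3,4-dichlorophenyl compound (no change at the digits printed from compound 1 to compound 4 (within the scatter)), so the chain amine of compound 2 does not carry over to this ring amine. Nothing available explains this loss.

Open, as far as these compounds go, is whether morpholin-4-yl, pyrrolidin-1-yl or a longer chain ending in piperidin-1-yl restores any response.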